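The source may hold more compounds than are shown below. What is called first, only, known or untested is meant among the compounds shown, and "the series" means these compounds.

Of the compounds shown here, two of one shared core have been measured in a functional assay; a lower number here means a stronger inhibitor, a higher number a weaker inhibitor. Compound 1 `CN(C)c1ccc(C2C(C#N)=C(N)OC(c3c[nH]c4ccccc34)=C2C#N)cc1` gives 900 ug/mL in this assay. Compound 2 `Cc1ccccc1C1C(C#N)=C(N)OC(c2c[nH]c3ccccc23)=C1C#N` reaches only the limit of this assay, reported as > 1000 ug/mL, which is a limit and not a number. Going by the values given here, the one measured step, an at least 1.1-fold higher number from compound 1 to compound 2 (0.04 log units; that floor lies within the scatter), tells how compound 2 stands: it sits at the limit, as noted in the limit of > 1000 ug/mL in this assay, at which 1 of the 2 values shown sits, so its true value is known only from one side.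

Compound 3 `COc1ccc(C2C(C#N)=C(N)OC(c3c[nH]c4ccccc34)=C2C#N)cc1` differs from compound 2 in one place: 4-methoxyphenyl in place of 2-methylphenyl on a saturated ring carbon. Among the compounds with values here, no measured step touches a 4-methoxyphenyl group, and the only step in this assay ends at a limit, so it can set no direction. Compound 1 and compound 2 show that both of the groups measured so far leave the core near or at the limit. Compound 3 is therefore expected to stay in the same region, with a step of a number no higher from compound 2 to compound 3 (the limit leaves the size open). The estimate for compound 3 in this assay is 1000 ug/mL, within 600 ug/mL to 2500 ug/mL.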

Compound 3, half-maximal inhibitory concentration: 859 ug/mL
For compound 3 the middle estimate is 1.2-fold (0.07 log units) above the measured one, within the range that was stated.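

In this assay, compound 3 gives 859 ug/mL, so a second 4-substituted phenyl group on the saturated ring carbon yields a readable value in the same high region as compound 1. Methoxy in place of dimethylamino on an aromatic carbon gives a 1.0-fold lower number from compound 1 to compound 3 (0.02 log units; within the scatter), so the two groups cannot be told apart here, and this exchange at the 4-position of the phenyl ring has no readable effect. 4-Methoxyphenyl in place of 2-methylphenyl gives an at least 1.1-fold lower number from compound 2 to compound 3 (0.06 log units; that floor lies within the scatter), and the true size of this step stays unknown because compound 2 is held only by a limit: the limit of > 1000 ug/mL in this assay, at which 1 of the 3 values shown sits.

From the compounds shown here alone, all three compounds carry a substituted phenyl group on this ring carbon, so it remains open whether a different kind of group there, such as a phenyl ring bearing a carboxylic acid or a simple methyl in place of the whole ring, would bring the number down beyond the scatter. The compounds also leave open how much the 1H-indol-3-yl group, the amino group and the two cyano groups contribute, since all three stay the same throughout.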